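A few compounds are considered here, and "the series" means these few. Any claim that something is new, unique, unknown or untested is made for them only; others in the source may bear on it.

Compound 1 `O=C(OC1CCC(CN2CCN(c3cc(=O)c4cc(C(F)(F)F)cc([N+](=O)[O-])c4s3)CC2)CC1)c1ccccc1`: 56.4%
Compound 2 `NC1CCC(CN2CCN(c3cc(=O)c4cc(C(F)(F)F)cc([N+](=O)[O-])c4s3)CC2)CC1`: 83.6%
Compound 3 `O=C(NC1CCC(CN2CCN(c3cc(=O)c4cc(C(F)(F)F)cc([N+](=O)[O-])c4s3)CC2)CC1)c1ccccc1`: 92.9%

In an ADME assay on cells (Hepatocyte, Homo sapiens) for metabolic stability, with a stated time of 30 min (on this read-out lower numbers stand for a less stable compound and higher numbers for a more stable compound), compound 2 stands second highest of the three. Compound 3 is its nearest neighbour, with a number 9.3 percentage points higher from compound 2 to compound 3 (within the scatter), while compound 1 is furthest away and beyond the scatter. Compound 4 `COc1ccc(C(=O)OC2CCC(CN3CCN(c4cc(=O)c5cc(C(F)(F)F)cc([N+](=O)[O-])c5s4)CC3)CC2)cc1` differs from compound 2 in one place: ((4-methoxyphenyl)carbonyl)oxy in place of amino on a saturated ring carbon. The measured step that bears on this runs from compound 1 to compound 2, where amino replaced benzoyloxy on the same saturated ring carbon and gave a number 27.2 percentage points higher from compound 1 to compound 2 (beyond the scatter). The change to compound 4 goes the other way, with ((4-methoxyphenyl)carbonyl)oxy entering instead of plain benzoyloxy, so a fall of roughly that size is expected, a number 28.6 percentage points lower from compound 2 to compound 4 (beyond the scatter). Compound 4 is therefore estimated to give 55%, within 35% to 75%.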

Compound 4, percent of the compound remaining: 12.2%
For compound 4 the middle estimate is 42.8 percentage points above the measured one; the whole stated range lies above it.
By their numbers in this assay, from the lowest: compound 4; then compound 1; then compounds 2 and 3 (each within the scatter of the next).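

In this assay, the ester series responds to a change in its aromatic ring as well as to the atom linking it to the saturated ring: methoxy in place of hydrogen on an aromatic carbon gives a number 44.2 percentage points lower from compound 1 to compound 4 (beyond the scatter). The gaps to the amine and the amide are wider still, with a number 71.4 percentage points lower from compound 2 to compound 4 (beyond the scatter) and a number 80.7 percentage points lower from compound 3 to compound 4 (beyond the scatter). Nothing available explains this loss.

From the compounds shown here alone, whether a fluoro or chloro group on that aromatic carbon would have a similar effect remains open. So does whether methoxy would matter on the benzamide of compound 3.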